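Furan-2-yl for phenyl on the carbonyl carbon of compound 1

The source may report more compounds than this note shows. Statements on the series, on what has been measured and on what is new or still open speak of the compounds shown alone.

Going by the values given here, compound 1 `CC1=CC[C@H]2[C@H](CC[C@]2(C)O)C(C)(C)[C@@H]1CC[C@H]1[C@]2(C)CC[C@H](OC(=O)c3ccccc3)C(C)(C)O[C@H]2CC[C@@]1(C)O` is the one compound of this set with a measured number in a functional assay on MCF7 cells (Homo sapiens) for antiproliferative activity, read by MTT assay, with a stated time of 72 h; on this read-out higher numbers stand for weaker inhibition and lower numbers for stronger inhibition: there compound 1 gives 21000 nM. Compound 2 `CC1=CC[C@H]2[C@@H]1CC=C(C)[C@@H](CC[C@H]1[C@]3(C)CC[C@H](OC(=O)c4ccncc4)C(C)(C)O[C@H]3CC[C@@]1(C)O)C2(C)C` is the second compound tested. In this assay compound 2 gives > 50000 nM, which is a limit of the assay and not a number; (the limit of > 50000 nM in this assay, at which 1 of the 2 values shown sits). Compound 3 `CC1=CC[C@H]2[C@H](CC[C@]2(C)O)C(C)(C)[C@@H]1CC[C@H]1[C@]2(C)CC[C@H](OC(=O)c3ccco3)C(C)(C)O[C@H]2CC[C@@]1(C)O` carries the change (furan-2-yl in place of phenyl on a carbonyl carbon). Among the compounds with values here, no pair of measured compounds differs in one place, so no measured step offers a guide for this exchange. Its size is therefore not known from the data; since nothing shown speaks for either direction, the step from compound 1 to compound 3 in this assay is expected to stay within the usual scatter, a 1.0-fold higher number from compound 1 to compound 3 (0.02 log units; within the scatter). Compound 3 is accordingly estimated at 22000 nM in this assay, with a range from 8000 nM to 60000 nM.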

Compound 3, half-maximal inhibitory concentration: 25700 nM
Compound 3: the middle estimate sits 1.2-fold (0.07 log units) below what was measured, and the stated range covers the measured number.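

Furan-2-yl in place of phenyl on the carbonyl carbon gives the first step that can be read at this position in this assay, and it is a 1.2-fold higher number from compound 1 to compound 3 (0.09 log units; within the scatter). The two aromatic rings therefore cannot be told apart on this read-out, although the one that enters is five-membered and carries a hetero atom and a hydrogen-bond acceptor, whereas the one that leaves has neither. Nothing shown gives a reason for this outcome.

The compounds shown leave open whether a ring without aromatic character, such as cyclohexyl, or a short chain, such as methyl, would also stay within the scatter of compound 1 on the same carbonyl carbon. They also leave open whether an amide in place of the benzoyloxy link, or a free hydroxyl group, would give a similar number.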